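Swapping the group on an aromatic carbon

The compounds below may be only part of what the source reports. "The series", "measured", "known", "first", "only" and "open" are said of these compounds alone.

Compound 1 `CCCNC(=O)c1ccc(-c2ccc(Cl)cc2)c(COc2ccc(-c3nc4cc(C(=O)O)ccc4n3C3CCCCC3)c(F)c2)c1` gives 24000 nM
Compound 2 `CN(C)C(=O)c1ccc(-c2ccc(Cl)cc2)c(COc2ccc(-c3nc4cc(C(=O)O)ccc4n3C3CCCCC3)c(F)c2)c1` gives 26000 nM
Compound 3 `O=C(O)c1ccc2c(c1)nc(-c1ccc(OCc3cc(C(=O)N4CCC(O)CC4)ccc3-c3ccc(Cl)cc3)cc1F)n2C1CCCCC1` gives 26000 nM

Level with compound 2, compound 3 stands at 26000 nM in a functional assay on Huh-5-2 cells (Homo sapiens), read by MTT assay (on this read-out higher numbers stand for lower toxicity in this test and lower numbers for higher toxicity in this test), and compound 1 lies within the scatter of both. The next compound to be tested is compound 4 `CC(=O)N(C)c1ccc(-c2ccc(Cl)cc2)c(COc2ccc(-c3nc4cc(C(=O)O)ccc4n3C3CCCCC3)c(F)c2)c1` and its structural change from compound 3 is acetyl(methyl)amino in place of (4-hydroxypiperidin-1-yl)carbonyl on an aromatic carbon and in words it is acetyl(methyl)amino in place of (4-hydroxypiperidin-1-yl)carbonyl on an aromatic carbon, para to a 4-chlorophenyl group.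

Among the compounds with values here, three measured steps bear on this change, all of them swaps on a carbonyl carbon. Dimethylamino in place of propylamino gives a 1.1-fold higher number from compound 1 to compound 2 (0.03 log units; within the scatter) and 4-hydroxypiperidin-1-yl in place of propylamino gives a 1.1-fold higher number from compound 1 to compound 3 (0.03 log units; within the scatter) while 4-hydroxypiperidin-1-yl in place of dimethylamino gives no change at the digits printed from compound 2 to compound 3 (within the scatter) and so none of them leaves the scatter. Within the data shown here, no measured step replaces the whole group on the aromatic carbon, so these steps are only a loose guide.

Going by compound 3 at 26000 nM and those steps, no change beyond the scatter is expected in this assay and no direction can be named. The expected step is a 1.0-fold lower number from compound 3 to compound 4 (0.02 log units; within the scatter) and nothing larger is foreseen. For compound 4 the expected value is 25000 nM and the estimated range runs from 13000 nM to 45000 nM as a best guess.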

Compound 4, half-maximal cytotoxic concentration: 26000 nM
For compound 4 the middle estimate is 1.0-fold (0.02 log units) below the measured one, and the stated range covers the measured number.
By their numbers in this assay, from the lowest: compounds 1, 2, 3 and 4 (each within the scatter of the next).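

Up to now only the amine part on a carbonyl carbon had varied, while compound 4 replaces the whole group on the aromatic carbon para to a 4-chlorophenyl group, so the substituent now joins the ring through its nitrogen rather than through its carbonyl carbon. In this assay this swap gives no change at the digits printed from compound 3 to compound 4 (within the scatter), and the comparisons with the two other amides give no change at the digits printed from compound 2 to compound 4 (within the scatter) and a 1.1-fold higher number from compound 1 to compound 4 (0.03 log units; within the scatter). The read-out therefore stays flat even when a group of 9 heavy atoms, with a six-membered ring and 1 hydrogen-bond donor, gives way to one of 5 heavy atoms with no ring and 0 hydrogen-bond donors, so among these four compounds neither the direction of the amide nor that ring sets the number. Nothing available explains why the number stays put.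

Open, going by these compounds, is whether a free amine, a carboxylic acid or a longer alkyl chain on this aromatic carbon would leave the number within the scatter as well. Also open, on these data alone, is whether the same flat picture would hold with something other than the 4-chlorophenyl group on the ring.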